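The compounds below may be only part of what the source reports. "The series", "measured", "known", "first", "only" and "open" are said of these compounds alone.

Measured compounds:
compound 1 `CN(C)C(=O)c1cc(-c2cnc(NCc3c(F)ccc4c3CCO4)c3cn[nH]c(=O)c23)n(C)n1`: 3000 nM
compound 2 `O=C(Nc1ccccc1)c1cnc(NCc2c(F)ccc3c2CCO3)n2cnnc12`: < 1000 nM
compound 3 `Cc1ncccc1-c1cnc(NCc2c(F)ccc3c2CCO3)c2n[nH]c(=O)n12`: < 2000 nM

Of the compounds shown here, three built on a shared core have been tested in a physicochemical assay for solubility, read by LC-MS, in phosphate buffer, with a stated time of 24 h, at pH 7.4; on this read-out lower numbers stand for lower solubility and higher numbers for higher solubility. Compound 1 gives 3000 nM, a definite number. For compound 2 the read-out is only a limit, < 1000 nM, the point marked at the limit of < 1000 nM in this assay, at which 1 of the 3 values shown sits. For compound 3 the read-out is likewise a limit, < 2000 nM, the point marked at the limit of < 2000 nM in this assay, at which 1 of the 3 values shown sits. Compound 2 thus stands at a limit rather than at a number, and one of the other two values is a limit as well. No two of these compounds differ in a single place, so no measured step can be drawn between them.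

Compound 4 `CC1(C)CC(=O)N(c2cnc(NCc3c(F)ccc4c3CCO4)n3cnnc23)C1` is not yet measured. It differs from compound 2 in one place: 4,4-dimethyl-2-oxopyrrolidin-1-yl in place of phenylcarbamoyl on an aromatic carbon. With compound 2 known only as a limit, the step can not be anchored firmly. A modest rise in this assay, somewhat beyond the usual scatter, is expected, and the step from compound 2 to compound 4 is estimated as an at least 3.0-fold higher number from compound 2 to compound 4 (0.47 log units; beyond the scatter). Compound 4 is expected to give about 3000 nM, within a range from 600 nM to 15000 nM.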

Compound 4, solubility: 57000 nM
Beside the measured number, compound 4's estimate is 19-fold (1.28 log units) below it; measured number above the stated range.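

In this assay, among these compounds, putting 4,4-dimethyl-2-oxopyrrolidin-1-yl in place of phenylcarbamoyl on this aromatic carbon gives an at least 57-fold higher number from compound 2 to compound 4 (1.75 log units; beyond the scatter) as the only measured step here, so a single change at this place can move the read-out by a large amount. The change removes a six-membered aromatic ring of carbon only and a hydrogen-bond donor, and brings in a five-membered non-aromatic ring with no donor. As far as these compounds go, compound 2 stands at a limit and not at a number, so the true size of the step stays unknown: the limit of < 1000 nM in this assay, at which 1 of the 4 values shown sits.

Compound 2 and compound 4 differ in the ring and the donor at once, and the compounds shown do not separate the two. Also open, from the compounds shown here alone, is how a plain 2-oxopyrrolidin-1-yl group without the two methyl groups, or a carboxylic acid or an amine such as morpholine, would read at this carbon.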